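This account rests on a few compounds, and the source may have more. Where it says the series, first, only, none or still open, it means among the compounds named here.

Values in a functional assay on HeLa cells (Homo sapiens) for cytotoxicity, read by MTT assay; a higher number here means a weaker inhibitor, a lower number a stronger inhibitor:
- compound 1 `CCCC(O)CC(=O)O[C@H](CC=C(C)C)C1=CC(=O)c2c(O)ccc(O)c2C1=O` gives 59300 nM
- compound 2 `COC(C)CO[C@H](CC=C(C)C)C1=CC(=O)c2c(O)ccc(O)c2C1=O` gives 53400 nM
- compound 3 `CC(C)=CC[C@@H](OC[C@@H](C)O)C1=CC(=O)c2c(O)ccc(O)c2C1=O` gives 22500 nM

Compound 1 and compound 2 sit level at the upper end of these numbers (a 1.1-fold lower number from compound 1 to compound 2 (0.05 log units; within the scatter)), and compound 3 lies lower (a 2.6-fold lower number from compound 1 to compound 3 (0.42 log units; beyond the scatter)). Compound 4 `CCCCC(CC(=O)O[C@H](CC=C(C)C)C1=CC(=O)c2c(O)ccc(O)c2C1=O)OC(C)=O` is not yet measured. Its change from compound 1 (1-acetoxypentyl in place of 1-hydroxybutyl on a saturated chain carbon bound to a carbonyl carbon) is 1-acetoxypentyl in place of 1-hydroxybutyl on a saturated chain carbon bound to a carbonyl carbon. Among the compounds with values here, no measured step covers this change. The nearest is 1-hydroxyethyl in place of 1-methoxyethyl (a 2.4-fold lower number from compound 2 to compound 3 (0.38 log units; beyond the scatter)), a modest step. Read in reverse, it hints at a slightly higher number when the hydroxy is capped, yet compound 1 already stands at the upper end. No step beyond the scatter is therefore expected in this assay for this change. The expected step is small (a 1.2-fold lower number from compound 1 to compound 4 (0.07 log units; within the scatter)). Compound 4 is estimated at 50000 nM (range 22000 nM to 110000 nM).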

Compound 4, half-maximal inhibitory concentration: 73500 nM
Beside the measured number, compound 4's estimate is 1.5-fold (0.17 log units) below it; the range from low to high includes it.
By their numbers in this assay, from the lowest: compound 3; then compounds 2, 1 and 4 (each within the scatter of the next).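

Replacing 1-hydroxybutyl with 1-acetoxypentyl on a saturated chain carbon bound to a carbonyl carbon gives a 1.2-fold higher number from compound 1 to compound 4 (0.09 log units; within the scatter) in this assay. This position therefore accepts the larger group, which has 0 hydrogen-bond donors, with no step beyond the scatter. No evidence on this result is available.

This single change alters both the chain and the capping of the hydroxy, so the two remain unseparated. As far as these compounds go, how an amine or a carboxylic acid at this position would read in this assay remains open.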